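The compounds below may be only part of what the source reports. "The series", "measured", "known", "first", "only" and "open" are said of these compounds alone.

Working notes on the amides of the shared core, read in a functional assay on HCT-116 cells (Homo sapiens) for antiproliferative activity, read by MTT assay, with a stated time of 72 h; on this read-out higher numbers stand for weaker inhibition and lower numbers for stronger inhibition. Compound 1 `CCNC(=O)CCc1cccc2c1B(O)OC2` gives only a limit of the assay, > 100000 nM. Compound 2 `CC(C)(C)NC(=O)CCc1cccc2c1B(O)OC2` also gives only a limit, > 100000 nM. Going by the values given here, compound 3 `O=C(CCc1cccc2c1B(O)OC2)Nc1ccc(Br)cc1` gives 46000 nM, the one true number so far, as the limit of > 100000 nM in this assay, at which 2 of the 3 values shown sit, makes plain.

Next is compound 4 `O=C(CCc1cccc2c1B(O)OC2)Nc1ccc(I)cc1`, with iodo in place of bromo on an aromatic carbon, para to a large group: iodo in place of bromo on an aromatic carbon.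

Among the compounds with values here, no measured step exchanges one halogen for another. The nearest evidence is an at least 2.1-fold lower number from compound 1 to compound 3 (0.33 log units; beyond the scatter) and an at least 2.1-fold lower number from compound 2 to compound 3 (0.33 log units; beyond the scatter). Both replace an alkyl group on the amide nitrogen with 4-bromophenyl, and both are bounded by limits. They suggest that the aryl amide matters, but they say nothing direct about the halogen. In this assay, no change beyond the scatter is therefore expected, and no direction is favoured from compound 3 at 46000 nM. The expected step is a 1.2-fold lower number from compound 3 to compound 4 (0.06 log units; within the scatter). For compound 4 the estimated value is 40000 nM, with an expected range of 17000 nM to 95000 nM.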

Compound 4, half-maximal inhibitory concentration: 50000 nM
Compound 4: middle estimate off by 1.3-fold (0.10 log units), on the low side, and the stated range covers the measured number.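

Going by these compounds alone, the first direct halogen exchange at this place, on an aromatic carbon para to a large group, gives a 1.1-fold higher number from compound 3 to compound 4 (0.04 log units; within the scatter), so this assay does not separate iodo from bromo here. Against the alkyl amides, compound 4 offers only floors, an at least 2.0-fold lower number from compound 2 to compound 4 (0.30 log units; that floor lies within the scatter) and an at least 2.0-fold lower number from compound 1 to compound 4 (0.30 log units; that floor lies within the scatter), and neither floor clears the scatter on its own. The true size of these two steps stays unreadable because both alkyl amides give only a limit: the limit of > 100000 nM in this assay, at which 2 of the 4 values shown sit.

On these data alone, whether the halogen contributes at all remains open, and a plain phenyl amide, or fluoro or chloro in the same place, would bear on that. Also open, as far as these compounds go, is how far the amide and its chain matter, which a carboxylic acid or a longer chain would address.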